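The source may hold more compounds than are shown below. What is called first, only, known or untested is meant among the compounds shown, and "the series" means these compounds.

Compound 1 `COc1cc2ncnc(NNC(=S)NC(=O)c3ccc(C(F)(F)F)cc3)c2cc1OC`: in a functional assay on KB cells (Homo sapiens) for cytotoxicity, read by MTT assay, with a stated time of 72 h (on this read-out higher numbers stand for weaker inhibition and lower numbers for stronger inhibition), compound 1 gives 8840 nM
Compound 2 `COc1cc2ncnc(NNC(=S)NC(=O)c3ccccc3C)c2cc1OC`: in this assay compound 2 gives 11400 nM

Of these two numbers, compound 2 has the higher one, yet the step of a 1.3-fold higher number from compound 1 to compound 2 (0.11 log units; within the scatter) lies within the scatter, so the two compounds cannot be told apart on this read-out. Compound 3 `COc1cc2ncnc(NNC(=S)NC(=O)c3ccc(F)cc3)c2cc1OC` has not been measured. It differs from compound 2 at one place: 4-fluorophenyl in place of 2-methylphenyl on a carbonyl carbon. Among the measured compounds shown here, the only measured step that bears on swapping the ring on the carbonyl carbon is a 1.3-fold higher number from compound 1 to compound 2 (0.11 log units; within the scatter), and it was small. Compound 3 is therefore expected to stay close to compound 2, with an expected step of a 1.2-fold lower number from compound 2 to compound 3 (0.08 log units; within the scatter). The estimate for compound 3 in this assay is 9500 nM, expected to fall between 4500 nM and 20000 nM.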

Compound 3, half-maximal inhibitory concentration: 4530 nM
For compound 3 the middle estimate is 2.1-fold (0.32 log units) above the measured one; the measured number falls inside the stated range.
By their numbers in this assay, from the lowest: compounds 3, 1 and 2 (each within the scatter of the next, the first and the last beyond it).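

In this assay, among the compounds shown here, the ring on the carbonyl carbon can shift the number after all: 4-fluorophenyl in place of 2-methylphenyl gives a 2.5-fold lower number from compound 2 to compound 3 (0.40 log units; beyond the scatter) and is the first step here beyond the scatter, though a modest one. Fluoro in place of trifluoromethyl on an aromatic carbon gives a 2.0-fold lower number from compound 1 to compound 3 (0.29 log units; within the scatter) and stays within the scatter, so that change cannot be resolved on this read-out. Nothing measured here explains the ring effect.

The compounds shown cannot separate gaining the fluoro from losing the methyl. On these data alone, how an amine or a carboxylic acid on this ring would behave also remains open.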